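Fluoro step from compound 1 to compound 4

This account rests on a few compounds, and the source may have more. Where it says the series, first, only, none or still open, it means among the compounds named here.

Values so far in a functional assay on SiHa cells (Homo sapiens) for inhibition, read by CCK-8 assay, with a stated time of 72 h, tested at 1 uM (a lower number here means less inhibition of growth, a higher number more inhibition of growth at the concentration tested), for the three measured compounds:
Compound 1 `CN(C)C(=O)c1cc2cnc(Nc3ccc(NC(=O)C4(C(=O)Nc5ccc(F)cc5)CC4)cc3)nc2n1C1CCCC1` gives 36.5% here
Compound 2 `CN(C)C(=O)c1cc2cnc(Nc3ccc(NC(=O)C4(C(=O)Nc5cccc(Cl)c5)CC4)cc3)nc2n1C1CCCC1` gives 16.2% here
Compound 3 `CN(C)C(=O)c1cc2cnc(Nc3ccc(NC(=O)C4(C(=O)Nc5ccc(Cl)c(C(F)(F)F)c5)CC4)cc3)nc2n1C1CCCC1` gives -11.2% here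

Compound 1 stands highest of the three, and both others lie beyond the scatter from it. Compound 4 `CN(C)C(=O)c1cc2cnc(Nc3ccc(NC(=O)C4(C(=O)Nc5ccc(F)cc5)CC4)cc3F)nc2n1C1CCCC1` carries one change: fluoro in place of hydrogen on an aromatic carbon in the form of fluoro in place of hydrogen on an aromatic carbon, ortho to a large group and meta to a large group. For the measured compounds named here, no measured step touches this ring. The available steps all replace the 4-fluorophenyl on an amide-type nitrogen: a number 20.3 percentage points lower from compound 1 to compound 2 (beyond the scatter) was modest, a number 47.7 percentage points lower from compound 1 to compound 3 (beyond the scatter) was large, and a number 27.4 percentage points lower from compound 2 to compound 3 (beyond the scatter) was modest. They show that this assay can move with substitution elsewhere, but they give no direct size for this change. A slight fall or no change beyond the scatter is expected, with wide uncertainty. The expected step is a number 4.5 percentage points lower from compound 1 to compound 4 (within the scatter) by this estimate. For compound 4 the estimate is 32% with an expected range from 11% to 51% in this read-out.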

Compound 4, percent growth inhibition at one concentration: 6.6%
Beside the measured number, compound 4's estimate is 25.4 percentage points above it; the measured number lies below the stated range.
By their numbers in this assay, from the lowest: compound 3; then compounds 4 and 2 (each within the scatter of the next); then compound 1.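

In this assay, fluoro in place of hydrogen on an aromatic carbon, ortho to a large group and meta to a large group, gives a number 29.9 percentage points lower from compound 1 to compound 4 (beyond the scatter) and so has a real effect at this position. The earlier steps shown here all changed the aryl group on the amide-type nitrogen, whereas this one shows that the read-out also responds to a single added fluorine on the six-membered aromatic ring of carbon only. Nothing available bears on the reason for this fall.

Still open, on these data alone, is whether the fall is specific to fluoro or would also follow from another group on this carbon, such as chloro, methoxy or an amine. Also open, as far as these compounds go, is whether the same fluoro change would carry over to compound 2 or compound 3, with their other aryl groups on the amide-type nitrogen.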